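This account rests on a few compounds, and the source may have more. Where it says the series, first, only, none or still open, it means among the compounds named here.

Among the measured compounds shown here, compound 3 `Cc1cccc(-c2nc(CN3CCC(C(=O)NCCCN4C[C@H](C)C[C@H](C)C4)CC3)c(C)o2)c1` stands highest of the three numbers so far in an ADME assay on Huh7.5.1 cells (Homo sapiens) for cytotoxicity, read by ATP content, with a stated time of 48 h (on this read-out lower numbers stand for higher toxicity in this test and higher numbers for lower toxicity in this test), where compound 3 gives 16500 nM. Its nearest neighbour is compound 2 `Cc1oc(-c2c(Cl)cccc2Br)nc1CN1CCC(C(=O)NCCCN2C[C@H](C)C[C@H](C)C2)CC1`, which in this assay gives 12200 nM, and a 1.4-fold higher number from compound 2 to compound 3 (0.13 log units; within the scatter). The furthest is compound 1 `Cc1ccc(C)c(-c2nc(CN3CCC(C(=O)NCCCN4C[C@H](C)C[C@H](C)C4)CC3)c(C)o2)c1`, which in this assay gives 4070 nM; here a 4.1-fold higher number from compound 1 to compound 3 (0.61 log units; beyond the scatter). Compound 4 `COc1ccc(-c2nc(CN3CCC(C(=O)NCCCN4C[C@H](C)C[C@H](C)C4)CC3)c(C)o2)cc1OC` differs from compound 3 in one place: 3,4-dimethoxyphenyl in place of 3-methylphenyl on an aromatic carbon. All three measured steps alter the group on that same aromatic carbon of the shared core: a 3.0-fold higher number from compound 1 to compound 2 (0.48 log units; beyond the scatter) and a 4.1-fold higher number from compound 1 to compound 3 (0.61 log units; beyond the scatter) were modest, while a 1.4-fold higher number from compound 2 to compound 3 (0.13 log units; within the scatter) stayed inside the scatter. For the measured compounds named here, none of them brings in a methoxy group, so there is no direct precedent for 3,4-dimethoxyphenyl. One therefore expects only a modest shift, if any, in this assay for compound 4, with no clear direction, and estimates the step as a 1.1-fold lower number from compound 3 to compound 4 (0.04 log units; within the scatter). Compound 4 is expected to give about 15000 nM, within a range from 5000 nM to 45000 nM.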

Compound 4, half-maximal cytotoxic concentration: 57200 nM
The estimate for compound 4 lay 3.8-fold (0.58 log units) below the measured number, and the stated range ends below it.
By their numbers in this assay, from the lowest: compound 1; then compounds 2 and 3 (each within the scatter of the next); then compound 4.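

In this assay, 3,4-dimethoxyphenyl on this aromatic carbon of the five-membered ring gives the highest number of the four compounds, with a 3.5-fold higher number from compound 3 to compound 4 (0.54 log units; beyond the scatter) and a 4.7-fold higher number from compound 2 to compound 4 (0.67 log units; beyond the scatter). The widest step of the series, a 14-fold higher number from compound 1 to compound 4 (1.15 log units; beyond the scatter), is large, whereas every earlier step was modest or stayed within the scatter, so changing this one group can move the number further than the first three compounds suggested. No measurement offered here explains why the number rises with this group.

Among the compounds shown here, with only one methoxy-bearing compound, it remains open whether the rise needs both methoxy groups or would appear with a single one. Going by these compounds, it is also open how a phenyl ring carrying an amine or a carboxylic acid at this place would read in this assay.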